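This account rests on a few compounds, and the source may have more. Where it says the series, first, only, none or still open, it means among the compounds named here.

Measured so far:
compound 1, `COc1cc2c(cc1OC)C(CC(=O)Nc1cccc(C)c1)CC2`: 29%
compound 2, `COc1cc2c(cc1OC)C(CC(=O)Nc1cccnc1)CC2`: 30%

In a functional assay on the whole organism (strain Wistar) for inhibition, with Rattus norvegicus as the target, read by paw edema, with a stated time of 2 h, at a dose of 100 mg/kg (on this read-out higher numbers stand for more inhibition at the one dose given (going by the name of the read-out) and lower numbers for less inhibition), compound 2 gives 30%, and in the same assay compound 1 gives 29%. Going by the values given here, the only measured step, a number 1 percentage points higher from compound 1 to compound 2 (within the scatter), lies within the scatter, so compound 2 stands alongside compound 1 rather than apart from it.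

Compound 3, `COc1cc2c(cc1OC)C(CC(=O)Nc1ccncc1)CC2`, differs from compound 2 in one place: pyridin-4-yl in place of pyridin-3-yl on an amide-type nitrogen. Among the compounds with values here, no measured step moves the ring nitrogen within the pyridine, so this change has no direct precedent. Within the data shown here, the one step that does bear on it, a number 1 percentage points higher from compound 1 to compound 2 (within the scatter), exchanged one aromatic group on the amide nitrogen for another and produced no change beyond the scatter. On that basis compound 3 is expected to show no step beyond the scatter, no change at the digits printed from compound 2 to compound 3 (within the scatter). For compound 3 the estimate in this assay is 30%, with a range from 15% to 45%.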

Compound 3, a percentage reported as inhibition, in the whole organism at one dose (the size of the read-out at that dose, not a potency): 44%
Estimate against measurement, compound 3: 14 percentage points below; low and high end bracket the measured number.
By their numbers in this assay, from the lowest: compounds 1 and 2 (each within the scatter of the next); then compound 3.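

In this assay, the place of the ring nitrogen within the pyridine proves to matter: pyridin-4-yl in place of pyridin-3-yl on the amide-type nitrogen gives a number 14 percentage points higher from compound 2 to compound 3 (beyond the scatter), even though the two groups have the same atoms and the same counts of hydrogen-bond donors and acceptors. Replacing 3-methylphenyl with pyridin-4-yl gives a number 15 percentage points higher from compound 1 to compound 3 (beyond the scatter), whereas replacing it with pyridin-3-yl gives only a number 1 percentage points higher from compound 1 to compound 2 (within the scatter), so among these three compounds a pyridine ring alone does not set a compound apart. Nothing available explains why moving this nitrogen changes the result.

On these data alone, whether the higher number depends on a ring nitrogen at all remains open. An unsubstituted phenyl or a cyclohexyl group on the same nitrogen could help answer that, and a single dose cannot show how potency compares.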